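Isopropyl for chloro on the benzyl ring of compound 2

A few compounds are considered here, and "the series" means these few. Any claim that something is new, unique, unknown or untested is made for them only; others in the source may bear on it.

Compound 1, `CC(C)(C)c1ccc(CNC(=O)C(C)(C)c2ccc(NS(C)(=O)=O)c(F)c2)cc1`: 1070 nM
Compound 2, `CC(C(=O)NCc1ccc(Cl)cc1)c1ccc(NS(C)(=O)=O)c(F)c1`: 1060 nM

In an assay on CHO cells for displacement of a labelled ligand from transient receptor potential cation channel subfamily V member 1 (Rattus norvegicus) (on this read-out higher numbers stand for weaker inhibition and lower numbers for stronger inhibition), compound 2 gives 1060 nM, and compound 1 gives 1070 nM; the two numbers lie within the scatter of each other, so neither stands apart. Compound 3, `CC(C)c1ccc(CNC(=O)C(C)c2ccc(NS(C)(=O)=O)c(F)c2)cc1`, has not yet been measured in this assay. It differs from compound 2 in one place: isopropyl in place of chloro on an aromatic carbon. Among the compounds with values here, no measured pair shows this change, and compound 1 with its own large group on that ring sits close to compound 2, so little movement beyond the scatter is expected; compound 3 is expected at 800 nM, between 250 nM and 2500 nM, a step of a 1.3-fold lower number from compound 2 to compound 3 (0.12 log units; within the scatter).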

Compound 3, inhibition constant: 127 nM
Compound 3: the middle estimate sits 6.3-fold (0.80 log units) above what was measured; measured number outside the range, below it.
By their numbers in this assay, from the lowest: compound 3; then compounds 2 and 1 (each within the scatter of the next).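

In this assay, isopropyl in place of chloro on this aromatic carbon, para to a large group, gives an 8.3-fold lower number from compound 2 to compound 3 (0.92 log units; beyond the scatter). Within the data shown here, this is the first change at this position that can be read on its own, and it shows that the number responds to which of these two groups the ring carries. Nothing available explains the step. Going by these compounds, whether a methoxy group, a trifluoromethyl group or a longer chain at this position would give a lower number remains open. So does whether the same change would have a similar effect on another core.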